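A few compounds are considered here, and "the series" means these few. Any claim that something is new, unique, unknown or untested is made for them only; others in the source may bear on it.

Compound 1 `Cc1cc(C)cc(/C=C(/SCc2ccc(F)cc2)C(=O)c2ccc(Br)cc2)c1` is the starting point: in a functional assay on DU-145 cells (Homo sapiens) for inhibition, read by trypan blue exclusion, with a stated time of 96 h (on this read-out higher numbers stand for weaker inhibition of growth and lower numbers for stronger inhibition of growth), compound 1 gives 10000 nM. Compound 2 `COc1ccc(/C=C(/SCc2ccc(F)cc2)C(=O)c2ccc(Br)cc2)cc1` carries 4-methoxyphenyl in place of 3,5-dimethylphenyl on a double-bonded chain carbon bound to a double-bonded chain carbon and in this assay compound 2 gives 50000 nM, so that a 5.0-fold higher number from compound 1 to compound 2 (0.70 log units; beyond the scatter). Compound 3 `Cc1cc(C)cc(/C=C(\C(=O)c2ccc(Cl)cc2)S(=O)(=O)c2ccc(Br)cc2)c1` has a different core; how the core of compound 3 differs from that of compound 1 is not broken down here. In this assay compound 3 gives 10000 nM, a number within the scatter of compound 1. Compound 4 `COc1ccc(/C=C(\C(=O)c2ccc(Cl)cc2)S(=O)(=O)c2ccc(Br)cc2)cc1` is compound 3 with 4-methoxyphenyl in place of 3,5-dimethylphenyl on a double-bonded chain carbon bound to a double-bonded chain carbon, the same change as from compound 1 to compound 2, at the same place. Because a 5.0-fold higher number from compound 1 to compound 2 (0.70 log units; beyond the scatter), a step of similar size is expected here, estimated as a 4.0-fold higher number from compound 3 to compound 4 (0.60 log units; beyond the scatter). On that basis compound 4 is expected to give about 40000 nM, between 10000 nM and 150000 nM.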

Compound 4, concentration for 50% growth inhibition: 10000 nM
Estimate against measurement, compound 4: 4.0-fold (0.60 log units) above; the range from low to high includes it.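

On the core of compound 3, 4-methoxyphenyl in place of 3,5-dimethylphenyl gives no change at the digits printed from compound 3 to compound 4 (within the scatter) in this assay. The change therefore does not carry over in size from one core to the other: the same change on two cores in this assay, a 5.0-fold higher number (0.70 log units; beyond the scatter) from compound 1 to compound 2 and no change at the digits printed (within the scatter) from compound 3 to compound 4, 5.0-fold (0.70 log units) apart, beyond the scatter of two such steps

This rests on one pair on each core, and the two cores differ in more than one place, so it does not show which part of the core goes with the difference or how the change would behave on any further core. The compounds shown leave open how an amine or a carboxylic acid would fare in place of 3,5-dimethylphenyl on a double-bonded chain carbon bound to a double-bonded chain carbon. They also leave open whether such a group would give the same result on both cores.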